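A few compounds are considered here, and "the series" means these few. Any claim that something is new, unique, unknown or untested is made for them only; others in the source may bear on it.

Measured compounds:
compound 1, `Oc1cccc(-c2cc(-c3cccs3)cc(-c3cccc(O)c3)n2)c1`, 770 nM
compound 2, `Oc1cccc(-c2cc(-c3ccsc3)cc(-c3ccccc3O)n2)c1`, > 50000 nM

Both were tested in a functional assay on T47D cells (Homo sapiens) for cytotoxicity, read by CCK-8 assay; a lower number here means a stronger inhibitor, a higher number a weaker inhibitor. Compound 1 gives a numerical value, 770 nM. For compound 2 the result is only a limit of the assay, > 50000 nM, so its true value is not pinned down by a number. For the measured compounds named here, compound 2 therefore stands at the weak end of what has been seen so far, at the limit of > 50000 nM in this assay, at which 1 of the 2 values shown sits, and compound 1 is the only compound with a measured number.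

Compound 3, `Oc1cccc(-c2cc(-c3ccsc3)cc(-c3cccc(O)c3)n2)c1`, has not yet been measured. It is made from compound 2 by a single change: 3-hydroxyphenyl in place of 2-hydroxyphenyl on an aromatic carbon. After this change compound 3 carries two 3-hydroxyphenyl groups, as compound 1 does. Going by the values given here, no measured pair shows this exact change, so the size of the step is uncertain. Still, a step from compound 2 to compound 3 in this assay is expected to be large and toward stronger inhibition, an at least 33-fold lower number from compound 2 to compound 3 (1.52 log units; beyond the scatter), since compound 1 with its two 3-hydroxyphenyl groups reaches 770 nM. Compound 3 is estimated at 1500 nM, within a range from 300 nM to 10000 nM.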

Compound 3, half-maximal inhibitory concentration: 1510 nM
For compound 3 the middle estimate is 1.0-fold (0.00 log units) below the measured one, within the range that was stated.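

In this assay, the two hydroxyphenyl groups have the same atoms and the same counts, yet placing 3-hydroxyphenyl instead of 2-hydroxyphenyl on the aromatic carbon next to the ring nitrogen gives an at least 33-fold lower number from compound 2 to compound 3 (1.51 log units; beyond the scatter), so at this position the attachment pattern of the hydroxyphenyl group alone separates a compound with a measurable value from one without. Exchanging thiophen-2-yl for thiophen-3-yl gives a 2.0-fold higher number from compound 1 to compound 3 (0.29 log units; within the scatter), so these two groups cannot be told apart in this assay when two 3-hydroxyphenyl groups are present. The first step has a lower bound but no measured size, since the result for compound 2 is only a limit: the limit of > 50000 nM in this assay, at which 1 of the 3 values shown sits.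

Whether 2-hydroxyphenyl has an equally large effect alongside thiophen-2-yl remains open, as no compound shown combines those two groups. From the compounds shown here alone, it is also open how this position would respond to a phenyl ring carrying a methoxy group, an amine or a carboxylic acid in place of the hydroxyl group.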